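Benzylsulfanyl series: methyl for bromo on compound 1

A few compounds are considered here, and "the series" means these few. Any claim that something is new, unique, unknown or untested is made for them only; others in the source may bear on it.

Measured so far:
compound 1 `Cc1cc(Nc2cc(-c3ccccc3)[nH]n2)n2nc(SCc3ccc(Br)cc3)nc2n1`: 2720 nM
compound 2 `Cc1cc(Nc2cc(C(C)(C)C)[nH]n2)n2nc(SCc3ccc(Br)cc3)nc2n1`: 7290 nM

In a functional assay on MCF7 cells (Homo sapiens) for inhibition, read by MTT assay, with a stated time of 72 h (a lower number here means a stronger inhibitor, a higher number a weaker inhibitor), compound 1 gives 2720 nM, the lower of the two numbers. Compound 2 gives 7290 nM. Going by the values given here, the only measured step is a 2.7-fold higher number from compound 1 to compound 2 (0.43 log units; beyond the scatter), and it changes a different part of the core.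

Compound 3 `Cc1ccc(CSc2nc3nc(C)cc(Nc4cc(-c5ccccc5)[nH]n4)n3n2)cc1` differs from compound 1 by methyl in place of bromo on an aromatic carbon. Among the compounds with values here, no measured step touches this position, so there is no guide to its size or direction; a number close to compound 1 is expected. The expected step is a 1.2-fold higher number from compound 1 to compound 3 (0.07 log units; within the scatter). Compound 3 is estimated at 3200 nM, within 1300 nM to 8000 nM.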

Compound 3, half-maximal inhibitory concentration: 7290 nM
Compound 3: the middle estimate sits 2.3-fold (0.36 log units) below what was measured; the measured number falls inside the stated range.
By their numbers in this assay, from the lowest: compound 1; then compounds 2 and 3 (each within the scatter of the next).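

In this assay, the benzyl ring is a position that responds to substitution: replacing bromo with methyl, read as 4-bromobenzyl to 4-methylbenzyl, gives a 2.7-fold higher number from compound 1 to compound 3 (0.43 log units; beyond the scatter). The change swaps one heavy atom for another, yet the step is modest and beyond the scatter, with bromo the better of the two groups here. Nothing available accounts for this step.

Open, going by these compounds, is how chloro, methoxy or an amine would read at this place. Also open, on these data alone, is whether the same change carries over to compound 2, which has tert-butyl in place of phenyl.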